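Swapping the Dimethylphenyl Group for an Ethoxycarbonylphenyl Group

This account rests on a few compounds, and the source may have more. Where it says the series, first, only, none or still open, it means among the compounds named here.

Compound 1 `COc1cc(Nc2ncnc3c(NC(=O)Nc4ccc(C)c(C)c4)cccc23)cc(OC)c1`: 8.8 nM
Compound 2 `COc1cc(Nc2ncnc3c(NC(=O)Nc4ccccc4Cl)cccc23)cc(OC)c1`: 356 nM
Compound 3 `COc1cc(Nc2ncnc3c(NC(=O)Nc4ccc(Cl)cc4Cl)cccc23)cc(OC)c1`: 3060 nM

In a functional assay on RT-112 cells (Homo sapiens) for antiproliferative activity, read by MTT assay, with a stated time of 72 h (a lower number here means a stronger inhibitor of growth, a higher number a weaker inhibitor of growth), compound 1 gives the lowest of the three numbers, with a 40-fold higher number from compound 1 to compound 2 (1.61 log units; beyond the scatter) and a 350-fold higher number from compound 1 to compound 3 (2.54 log units; beyond the scatter) marking the gaps to its neighbours. Compound 4 `CCOC(=O)c1ccc(NC(=O)Nc2cccc3c(Nc4cc(OC)cc(OC)c4)ncnc23)cc1` keeps the shared core of compound 1 and differs only by 4-(ethoxycarbonyl)phenyl in place of 3,4-dimethylphenyl on an amide-type nitrogen. For the measured compounds named here, no measured step carries this exact change; the two steps that bear on it replace the same group with chlorinated rings and both lose strongly, as does an 8.6-fold higher number from compound 2 to compound 3 (0.93 log units; beyond the scatter) within that pair. A loss is therefore expected for compound 4 as well, though its size is uncertain, and compound 4 is estimated at 60 nM (range 9 nM to 500 nM), meaning an expected step of a 6.8-fold higher number from compound 1 to compound 4 (0.83 log units; beyond the scatter).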

Compound 4, concentration for 50% growth inhibition: 317 nM
Compound 4: the middle estimate sits 5.3-fold (0.72 log units) below what was measured; the range from low to high includes it.
By their numbers in this assay, from the lowest: compound 1; then compounds 4 and 2 (each within the scatter of the next); then compound 3.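

In this assay, a ring without chlorine also loses heavily against 3,4-dimethylphenyl, with a 36-fold higher number from compound 1 to compound 4 (1.56 log units; beyond the scatter), so the loss at this amide-type nitrogen is not confined to chlorinated rings. Among the replacements, 4-(ethoxycarbonyl)phenyl stands level with 2-chlorophenyl, with a 1.1-fold lower number from compound 2 to compound 4 (0.05 log units; within the scatter), and does better than 2,4-dichlorophenyl, with a 9.7-fold lower number from compound 3 to compound 4 (0.98 log units; beyond the scatter).

Nothing available explains this loss. Still open, on these data alone, is whether the ester matters at all: the matching carboxylic acid, a primary amide or a ring with a single methyl could separate the effect of adding the ester from that of removing the two methyl groups.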